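A few compounds are considered here, and "the series" means these few. Any claim that something is new, unique, unknown or untested is made for them only; others in the source may bear on it.

Compound 1 `CCCc1cc(N)c2cc(NC(=O)/C=C/c3ccc(C(C)C)cc3)ccc2n1`: 2.9 nM; compound 2 `CCCc1cc(N)c2cc(NC(=O)/C=C/c3cccc(Cl)c3)ccc2n1`: 1100 nM.

For the measured compounds named here, in an assay on isolated protein for displacement of a labelled ligand from melanin-concentrating hormone receptor 1 (Homo sapiens) (a higher number here means a weaker inhibitor, a lower number a stronger inhibitor), compound 2 gives the higher of the two numbers, and the only measured step bearing on it, a 380-fold higher number from compound 1 to compound 2 (2.58 log units; beyond the scatter), changed both the substituent and its position at once. Compound 3 `CCCc1cc(N)c2cc(NC(=O)/C=C/c3ccc(Cl)cc3)ccc2n1` differs from compound 2 by 4-chlorophenyl in place of 3-chlorophenyl on a double-bonded chain carbon bound to a double-bonded chain carbon. Whether the position or the substituent drove that step cannot be separated from these two numbers, so the direction is uncertain, but compound 3 is expected to move back toward compound 1 by a 7.3-fold lower number from compound 2 to compound 3 (0.87 log units; beyond the scatter). Compound 3 is therefore estimated at 150 nM, within 15 nM to 1200 nM.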

Compound 3, half-maximal inhibitory concentration: 6 nM
Estimate against measurement, compound 3: 25-fold (1.40 log units) above; the whole stated range lies above it.
By their numbers in this assay, from the lowest: compound 1; then compound 3; then compound 2.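

In this assay the chlorine's placement alone matters: a 180-fold lower number from compound 2 to compound 3 (2.26 log units; beyond the scatter) is a large step with the substituent unchanged, 4-chlorophenyl in place of 3-chlorophenyl. Keeping that placement, chloro in place of isopropyl on an aromatic carbon gives only a 2.1-fold higher number from compound 1 to compound 3 (0.32 log units; beyond the scatter) and is modest, though beyond the scatter. Most of the earlier drop from compound 1 to compound 2 therefore goes with the placement rather than with the change of substituent.

From the compounds shown here alone, whether a methoxy group or a carboxylic acid in place of the chloro of compound 3 would keep the number low remains open. No evidence is available on why the two chlorophenyl groups differ so sharply.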